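Exchanging the Aryl Tail of Compound 2

The source may hold more compounds than are shown below. What is called first, only, known or untested is meant among the compounds shown, and "the series" means these compounds.

Compound 2 `O=c1[nH]/c(=N\OCCCc2cccc([N+](=O)[O-])c2)ccn1[C@@H]1O[C@H](COP(=O)(O)OP(=O)(O)OP(=O)(O)O)[C@@H](O)[C@H]1O` carries a three-carbon chain that ends in a 3-nitrophenyl group. In a functional assay on 1321-N1 cells for agonist activity at P2Y purinoceptor 2 (Homo sapiens), read by scintillation counting and inositol phosphate accumulation (on this read-out higher numbers stand for an effect only at larger amounts of compound and lower numbers for an effect already at smaller amounts), compound 2 gives 457 nM. For the measured compounds named here, its only comparator is compound 1 `O=C(O)CCCO/N=c1/ccn([C@@H]2O[C@H](COP(=O)(O)OP(=O)(O)OP(=O)(O)O)[C@@H](O)[C@H]2O)c(=O)[nH]1`, which has a carboxy group where compound 2 has the aryl ring; in this assay compound 1 gives 299 nM. The change from the small acid to the aryl group produced a 1.5-fold higher number from compound 1 to compound 2 (0.18 log units; within the scatter). Compound 2 thus stands as the higher of the two numbers, but the gap to compound 1 lies within the scatter, so no order between the two can be claimed.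

Compound 3 `O=c1[nH]/c(=N\OCCCc2ccncc2)ccn1[C@@H]1O[C@H](COP(=O)(O)OP(=O)(O)OP(=O)(O)O)[C@@H](O)[C@H]1O` arises from compound 2 by pyridin-4-yl in place of 3-nitrophenyl on a saturated chain carbon, three bonds along the chain from an oxygen. Going by the values given here, the single measured step at this position, a 1.5-fold higher number from compound 1 to compound 2 (0.18 log units; within the scatter), was within the scatter, and it involved a far larger change of group than the one now considered. On that basis the step of a 1.1-fold lower number from compound 2 to compound 3 (0.06 log units; within the scatter) is expected to stay within the scatter, with no clear direction. Compound 3 is therefore estimated at 400 nM in this assay, with a range from 150 nM to 1100 nM.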

Compound 3, half-maximal effective concentration: 285 nM
The estimate for compound 3 lay 1.4-fold (0.15 log units) above the measured number, within the range that was stated.
By their numbers in this assay, from the lowest: compounds 3, 1 and 2 (each within the scatter of the next).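

In this assay, placing pyridin-4-yl on a saturated chain carbon, three bonds along the chain from an oxygen, gives a 1.6-fold lower number from compound 2 to compound 3 (0.21 log units; within the scatter), and setting it against the carboxy group gives a 1.0-fold lower number from compound 1 to compound 3 (0.02 log units; within the scatter); both steps lie within the scatter. The earlier pair had set only a carboxy group against 3-nitrophenyl, whereas compound 3 shows that an aromatic ring with a hetero atom at the chain end also cannot be told apart from either, so no order among the three compounds can be claimed and, across these three end groups, the number stays within the scatter. No supporting data bear on why these different groups give results that cannot be separated.

From the compounds shown here alone, all three compounds share the same chain, so what a longer chain or a shorter chain would do at this place stays open. Also open, going by these compounds, is how a plain phenyl ring, an amine at the chain end or a pyridin-2-yl group would compare, and whether any group at this place can move the number beyond the scatter.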